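Naphthyl for phenyl on the amine-bearing chain carbon

The source may report more compounds than this note shows. Statements on the series, on what has been measured and on what is new or still open speak of the compounds shown alone.

Compound 1 `O=S(=O)(NCCCNCC1COc2ccccc2O1)c1cc(C(F)(F)F)cc(C(F)(F)F)c1` and compound 2 `O=S(=O)(NCCCNCc1ccccc1)c1cc(C(F)(F)F)cc(C(F)(F)F)c1` share a core and differ only at the group on the saturated chain carbon bound to the amine nitrogen. Within the data shown here, in a functional assay on ASPC1 cells (Homo sapiens) for inhibition, read by MTT assay, with a stated time of 72 h (on this read-out lower numbers stand for stronger inhibition of growth and higher numbers for weaker inhibition of growth), compound 1 gives 2900 nM, and compound 2 gives 13000 nM; compound 2 thus stands at the highest of the two numbers, and the change a 4.5-fold higher number from compound 1 to compound 2 (0.65 log units; beyond the scatter) is the only step measured so far. Compound 3 `O=S(=O)(NCCCNCc1cccc2ccccc12)c1cc(C(F)(F)F)cc(C(F)(F)F)c1` carries the change (naphthalen-1-yl in place of phenyl on a saturated chain carbon bound to an amine nitrogen). Among the measured compounds shown here, the one measured step bears on it only loosely: it shows that a larger group at this position, in compound 1 at 2900 nM, went with the lower number. For the measured compounds named here, compound 3 is therefore expected to show a modest move toward lower numbers, a 2.6-fold lower number from compound 2 to compound 3 (0.41 log units; beyond the scatter), though no measured pair tests this exact group. The estimate for compound 3 in this assay is 5000 nM, with a range from 1500 nM to 16000 nM.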

Compound 3, concentration for 50% growth inhibition: 21000 nM
Beside the measured number, compound 3's estimate is 4.2-fold (0.62 log units) below it; measured number above the stated range.
By their numbers in this assay, from the lowest: compound 1; then compounds 2 and 3 (each within the scatter of the next).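

Working from this assay, the step of a 1.6-fold higher number from compound 2 to compound 3 (0.21 log units; within the scatter) lies within the scatter, so going from phenyl to naphthalen-1-yl, from 6 to 10 carbon heavy atoms, gives no readable change at this position, and the earlier link between a larger group and a lower number does not extend to compound 3. The step of a 7.2-fold higher number from compound 1 to compound 3 (0.86 log units; beyond the scatter) lies beyond the scatter, leaving compound 1 and its 2,3-dihydro-1,4-benzodioxin-2-yl group alone at the low end, with phenyl and naphthalen-1-yl together above it. Nothing on hand explains this separation.

Still open, on these data alone, is whether the lower number of compound 1 goes with the oxygen atoms of its ring or with the saturated ring itself. A 1,2,3,4-tetrahydronaphthalen-2-yl group on the same carbon would separate these two readings, and a pyridin-2-yl group would show whether a ring nitrogen can stand in for them.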